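This account rests on a few compounds, and the source may have more. Where it says the series, first, only, none or still open, it means among the compounds named here.

Three compounds share one core and were tested in a functional assay on SH-SY5Y cells (Homo sapiens) for cytotoxicity, read by MTT assay, with stated times of 8 h, 30 min and 12 h, tested at 5 uM; a higher number here means a stronger effect of the compound at the concentration tested, a lower number a weaker effect. Compound 1 `N=C(NCc1ccccc1)[C@@H]1CCC(=O)N1Cc1ccc(F)cc1` gives 31.4% in this assay. Compound 2 `N=C(NCc1ccc(O)cc1)[C@@H]1CCC(=O)N1Cc1ccc(F)cc1` gives 48.6% in this assay, and compound 3 `COc1ccc(CNC(=N)[C@@H]2CCC(=O)N2Cc2ccc(F)cc2)cc1` gives 38.1% in this assay, which places compound 3 second highest of the three: the step of a number 6.7 percentage points higher from compound 1 to compound 3 (within the scatter) lies within the scatter, while a number 10.5 percentage points lower from compound 2 to compound 3 (beyond the scatter) goes beyond it. Compound 4 `COc1ccc(CNC(=N)[C@@H]2CCC(=O)N2Cc2ccc(C)cc2)cc1` has not yet been measured. It differs from compound 3 by methyl in place of fluoro on an aromatic carbon. Among the measured compounds shown here, none of the measured steps changes the 4-fluorobenzyl: a number 17.2 percentage points higher from compound 1 to compound 2 (beyond the scatter), a number 6.7 percentage points higher from compound 1 to compound 3 (within the scatter) and a number 10.5 percentage points lower from compound 2 to compound 3 (beyond the scatter) all concern the hydroxy and methoxy. For the measured compounds named here, with no direct precedent, the expected step of a number 0.1 percentage points lower from compound 3 to compound 4 (within the scatter) is none beyond the scatter. Compound 4 is therefore estimated at 38%, with a range from 26% to 50%.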

Compound 4, a percentage reported as activity, at one concentration (the size of the read-out at that concentration, not a potency): 29.5%
Estimate against measurement, compound 4: 8.5 percentage points above; the measured number falls inside the stated range.
By their numbers in this assay, from the lowest: compounds 4, 1 and 3 (each within the scatter of the next); then compound 2.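

Among the compounds shown here, this is the first change at the 4-fluorobenzyl, and methyl in place of fluoro on this aromatic carbon gives in this assay a number 8.6 percentage points lower from compound 3 to compound 4 (within the scatter). With the methoxy in place, this exchange of one heavy atom therefore has no effect that can be told from the scatter. Nothing shown explains the size of this step.

As far as these compounds go, it remains open how a chloro, an amine or a carboxylic acid at this carbon would read out. The compounds also leave open whether methyl in place of fluoro would read the same alongside the hydroxy of compound 2.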